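Swapping an aryl acid for a methylimidazole on a piperidine core

The source may report more compounds than this note shows. Statements on the series, on what has been measured and on what is new or still open speak of the compounds shown alone.

Measured so far:
compound 1 `O=C(O)c1ccc(CN2CCC[C@H](OCc3cc(Cl)cc(Cl)c3)[C@@H]2c2ccccc2)s1`: 76000 nM
compound 2 `CN1CCC[C@H](OCc2cc(Cl)cc(Cl)c2)[C@@H]1c1ccccc1`: > 200000 nM
compound 3 `COc1ccc(C(=O)O)cc1CN1CCC[C@H](OCc2cc(Cl)cc(Cl)c2)[C@@H]1c1ccccc1`: 123000 nM

In an assay on isolated protein for activation of cGMP-dependent protein kinase 1 (Homo sapiens), read by ADP-Glo, with stated times of 120 min and 40 min (a lower number here means that less compound is needed, a higher number that more compound is needed for the effect), compound 3 gives 123000 nM. Among the two actual numbers this is the higher one, but its nearest neighbour is compound 1, and a 1.6-fold higher number from compound 1 to compound 3 (0.21 log units; within the scatter) sits within the scatter, so the two cannot be ranked. For compound 2 the assay reports only a limit, (the limit of > 200000 nM in this assay, at which 1 of the 3 values shown sits), not a number.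

Compound 4 `Cn1ccnc1CN1CCC[C@H](OCc2cc(Cl)cc(Cl)c2)[C@@H]1c1ccccc1` differs from compound 3 in one place: 1-methyl-1H-imidazol-2-yl in place of 5-carboxy-2-methoxyphenyl on a saturated chain carbon bound to an amine nitrogen in a ring. The steps measured so far show that the 5-carboxythiophen-2-yl group matters: an at least 2.6-fold higher number from compound 1 to compound 2 (0.42 log units; beyond the scatter), and an at least 1.6-fold lower number from compound 2 to compound 3 (0.21 log units; that floor lies within the scatter). Exchanging one carboxy-bearing aryl group for another, as in a 1.6-fold higher number from compound 1 to compound 3 (0.21 log units; within the scatter), changed little. Compound 4 keeps an aromatic group on that carbon but loses the carboxylic acid, which is the feature shared by the two compounds that returned actual numbers. For compound 4 in this assay the number is therefore expected to rise, with a fair chance that only a limit is reported, and the estimate is 200000 nM within 90000 nM to 450000 nM, meaning a 1.6-fold higher number from compound 3 to compound 4 (0.21 log units; within the scatter).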

Compound 4, half-maximal effective concentration: 165000 nM
Estimate against measurement, compound 4: 1.2-fold (0.08 log units) above; the range from low to high includes it.
By their numbers in this assay, from the lowest: compounds 1, 3 and 4 (each within the scatter of the next, the first and the last beyond it). At a limit, above all of these: compound 2.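

In this assay, replacing 5-carboxy-2-methoxyphenyl with 1-methyl-1H-imidazol-2-yl on this carbon gives a 1.3-fold higher number from compound 3 to compound 4 (0.13 log units; within the scatter), so a ring without a carboxylic acid cannot be told apart from this acid-bearing group, and an acid is not needed here for an actual number. Only the comparison with the other acid-bearing group reaches a modest size, with a 2.2-fold higher number from compound 1 to compound 4 (0.34 log units; beyond the scatter), although compound 3 and compound 4 cannot be separated. Placing 1-methyl-1H-imidazol-2-yl on this carbon in place of hydrogen gives an at least 1.2-fold lower number from compound 2 to compound 4 (0.08 log units; that floor lies within the scatter). Compound 2 has only a limit, not a number: the limit of > 200000 nM in this assay, at which 1 of the 4 values shown sits.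

On these data alone, it remains open whether the ring or the carboxylic acid matters more, which a plain phenyl group or an imidazole carrying a carboxylic acid could help to separate. A pyridine, or a longer chain carrying the imidazole, is also untested among the compounds shown.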